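This account rests on a few compounds, and the source may have more. Where it says the series, first, only, none or still open, it means among the compounds named here.

Compound 1 `C=CCc1c(OCC(C)=O)ccc2ccc(=O)oc12` gives > 20 ug/mL in an assay on LNCaP cells for inhibition of 3-oxo-5-alpha-steroid 4-dehydrogenase 1 (Homo sapiens) (a higher number here means a weaker inhibitor, a lower number a stronger inhibitor), which is a limit of that assay and not a number.
Compound 2 `C=CCc1c(OCc2ccccc2)ccc2ccc(=O)oc12` gives > 4 ug/mL in this assay, likewise only a limit.

Compound 2 thus stands at a limit with no number of its own. Because both values are limits, the step that the two limits leave unreadable from compound 1 to compound 2 cannot be read in size. Compound 3 `C=CCc1c(OC(C)(C)C=C)ccc2ccc(=O)oc12` differs from compound 2 by 1,1-dimethylprop-2-en-1-yl in place of benzyl on an oxygen on an aromatic ring. Within the data shown here, no measured step with a readable size bears on this change, so no shift beyond the scatter is expected in this assay in either direction. Compound 3 is therefore estimated at 10 ug/mL, with a range from 3 ug/mL to 40 ug/mL, most likely reported once more only as a limit. The expected step that the limit leaves unreadable from compound 2 to compound 3 is set at none.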

Compound 3, half-maximal inhibitory concentration: 13.6 ug/mL
For compound 3 the middle estimate is 1.4-fold (0.13 log units) below the measured one; the range from low to high includes it.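

With 1,1-dimethylprop-2-en-1-yl on this oxygen, compound 3 gives the first real number among the compounds shown, 13.6 ug/mL in this assay. Among these compounds, the one readable step is an at least 1.4-fold lower number from compound 1 to compound 3 (0.16 log units; that floor lies within the scatter), so this change establishes no real gain. The step involving compound 2 cannot be read, since that compound has only a limit: the limit of > 4 ug/mL in this assay, at which 1 of the 3 values shown sits.

On these data alone, the true values of compound 1 and compound 2 stay unknown. As far as these compounds go, whether an amine or a carboxylic acid on this oxygen would move the number also remains open.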